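A few compounds are considered here, and "the series" means these few. Any claim that something is new, unique, unknown or untested is made for them only; others in the source may bear on it.

Of the compounds shown here, three of a shared core have been tested in a functional assay on the whole organism with Rattus norvegicus as the target, at a dose of 20 mg/kg by the oral route; a higher number here means more inhibition at the dose given (going by the name of the read-out), a lower number less inhibition. Compound 1 `Cc1cccc2c1CC/C2=C\C(=O)NC1CC1` gives 7%, compound 2 `NC(=O)/C=C1\CCc2c(F)cccc21` gives 34%, and compound 3 `NC(=O)/C=C1\CCc2c(Cl)cccc21` gives 58%, the highest of the three numbers. Going by the values given here, the only single-point change measured so far, a number 24 percentage points higher from compound 2 to compound 3 (beyond the scatter), is a modest rise. Compound 4 `Cc1cccc2c1CC/C2=C\C(N)=O` differs from compound 3 by methyl in place of chloro on an aromatic carbon. Among the compounds with values here, no measured step exchanges a methyl for a chloro, so the size of this step is uncertain; compound 1 also carries a methyl, though with a different amide, and its number in this assay is low. For compound 4 a step of a number 23 percentage points lower from compound 3 to compound 4 (beyond the scatter) is expected, giving an estimate of 35%, with a range from 10% to 60%.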

Compound 4, a percentage reported as inhibition, in the whole organism at one dose (the size of the read-out at that dose, not a potency): 13%
For compound 4 the middle estimate is 22 percentage points above the measured one, and the stated range covers the measured number.
By their numbers in this assay, from the lowest: compounds 1 and 4 (each within the scatter of the next); then compound 2; then compound 3.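

At this aromatic carbon in this assay the choice of group matters greatly: methyl in place of chloro gives a large fall (a number 45 percentage points lower from compound 3 to compound 4 (beyond the scatter)), and methyl in place of fluoro a modest one (a number 21 percentage points lower from compound 2 to compound 4 (beyond the scatter)), so methyl sits below both halogens. With methyl kept, hydrogen in place of cyclopropyl on the amide-type nitrogen leaves the two amides indistinguishable (a number 6 percentage points higher from compound 1 to compound 4 (within the scatter)). Nothing available explains these differences. From the compounds shown here alone, whether bromo or methoxy at this carbon could match chloro stays open, as does how cyclopropyl on the amide behaves alongside chloro.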